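From 3-(trifluoromethyl)benzyl to (oxolan-2-yl)methyl

This account rests on a few compounds, and the source may have more. Where it says the series, first, only, none or still open, it means among the compounds named here.

Measured so far in a functional assay on U-87MG ATCC cells (Homo sapiens) for antiproliferative activity, with a stated time of 3 days (a higher number here means that more compound is needed for the effect, a lower number that less compound is needed), are these two compounds.
- Compound 1 `Oc1ccc(CN(Cc2cccc(C(F)(F)F)c2)Cc2ccc(O)c3ncccc23)c2cccnc12` (2 uM)
- Compound 2 `Oc1ccc(CN(Cc2cc(C(F)(F)F)cc(C(F)(F)F)c2)Cc2ccc(O)c3ncccc23)c2cccnc12` (< 0.2 uM as a limit of the assay)

For the measured compounds named here, compound 1 holds the only number in this assay so far, since compound 2 has only a limit. Compound 3 `Oc1ccc(CN(Cc2ccc(O)c3ncccc23)CC2CCCO2)c2cccnc12` differs from compound 1 by oxolan-2-yl in place of 3-(trifluoromethyl)phenyl on a saturated chain carbon bound to an amine nitrogen. Going by the values given here, one measured step bears on this change, an at least 10-fold lower number from compound 1 to compound 2 (1.00 log units; beyond the scatter) on the same arm, where trifluoromethyl replaces hydrogen on an aromatic carbon. Going by that step, losing the trifluoromethyl-bearing ring is expected to raise the number. Among the compounds with values here, no measured compound carries oxolan-2-yl, so the expected range stays wide. The estimated step is a 3.0-fold higher number from compound 1 to compound 3 (0.48 log units; beyond the scatter) towards a higher number. Compound 3 is expected at 6 uM (estimated range 1.5 uM to 25 uM).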

Compound 3, concentration for half-maximal effect: 5 uM
The estimate for compound 3 lay 1.2-fold (0.08 log units) above the measured number, and the stated range covers the measured number.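

This arm need not carry an aromatic ring: with oxolan-2-yl in place of 3-(trifluoromethyl)phenyl on a saturated chain carbon bound to an amine nitrogen, this assay shows a 2.5-fold higher number from compound 1 to compound 3 (0.40 log units; beyond the scatter). That step is smaller in size than an at least 10-fold lower number from compound 1 to compound 2 (1.00 log units; beyond the scatter), so among the compounds shown, adding a second trifluoromethyl moves the number further than exchanging the whole ring does. The non-aromatic ring with its hetero atom is therefore compatible with a measurable number on this arm, at least in compound 3.

Plain benzyl or cyclopentylmethyl on this arm would separate the loss of the trifluoromethyl from the loss of the aromatic ring and the gain of the ring oxygen, which the compounds shown cannot do. Compound 2 stands as a limit of the assay and not as a number, so the full size of its step stays open: the limit of < 0.2 uM in this assay, at which 1 of the 3 values shown sits.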